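The source may hold more compounds than are shown below. What is called first, only, known or untested is meant among the compounds shown, and "the series" means these compounds.

In a functional assay on PC-12 cells (Rattus norvegicus) for cytotoxicity, read by MTT assay, with stated times of 2 h and 24 h, tested at 10 uM (a lower number here means a weaker effect, a higher number a stronger effect of the compound at the concentration tested), compound 1 `Oc1cc(C(F)(F)F)ccc1-c1nc(-c2ccccc2O)n(-c2ccc(C(F)(F)F)cc2)n1` gives 102%, and compound 2 `Oc1cc(C(F)(F)F)ccc1-c1nc(-c2ccccc2O)n(-c2ccccc2F)n1` gives 100%. The two numbers sit within the scatter of each other, so on the numbers shown compound 2 stands level with compound 1, the only other measured compound. Among the measured compounds shown here, the step of a number 2 percentage points lower from compound 1 to compound 2 (within the scatter) is the one measured change at the aromatic nitrogen, and it did not move the read-out beyond the scatter.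

Compound 3 `COc1cccc(-n2nc(-c3ccc(C(F)(F)F)cc3O)nc2-c2ccccc2O)c1` has not yet been measured. It differs from compound 2 as follows: 3-methoxyphenyl in place of 2-fluorophenyl on an aromatic nitrogen. For the measured compounds named here, this change sits at the same aromatic nitrogen as the one measured step, which was within the scatter, so no step beyond the scatter is expected in this assay, in either direction, though a single step is thin evidence.

For compound 3 the expected value in this assay is 100%, with a range from 88% to 112%, which amounts to an expected step of no change at the digits printed from compound 2 to compound 3 (within the scatter).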

Compound 3, a percentage reported as activity, at one concentration (the size of the read-out at that concentration, not a potency): 106%
Beside the measured number, compound 3's estimate is 6 percentage points below it; the range from low to high includes it.
By their numbers in this assay, from the lowest: compounds 2, 1 and 3 (each within the scatter of the next).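

In this assay, 3-methoxyphenyl in place of 2-fluorophenyl on the aromatic nitrogen gives a number 6 percentage points higher from compound 2 to compound 3 (within the scatter) and 3-methoxyphenyl in place of 4-(trifluoromethyl)phenyl gives a number 4 percentage points higher from compound 1 to compound 3 (within the scatter). Until now, this position had carried only fluorine-bearing phenyl groups, whereas 3-methoxyphenyl brings oxygen and one hydrogen-bond acceptor, and the read-out still stays within the scatter across all three compounds. Nothing measured here explains why these groups read alike.

On these data alone, whether a phenyl group carrying an amine or a carboxylic acid, or a longer chain on this nitrogen, would give a step beyond the scatter stays open. Also open, as far as these compounds go, is how the read-out responds to changes elsewhere on the shared core, such as at the 2-hydroxyphenyl group.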